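Benzyl for dimethoxypropyl on a shared purine-type core

The compounds below may be only part of what the source reports. "The series", "measured", "known", "first", "only" and "open" are said of these compounds alone.

Measured so far:
compound 1 `COC(CCn1cnc2c(NCc3ccc(C(=O)Nc4ccccc4N)cc3)nc(Cl)nc21)OC`: 34.2%
compound 2 `CC(C)n1cnc2c(Nc3ccccc3)nc(NCOCc3ccc(/C=C/C(=O)Nc4ccccc4N)cc3)nc21`: 40.8%
compound 3 `CC1CCN(c2nc(Cl)nc3c2ncn3Cc2ccc(/C=C/C(=O)Nc3ccccc3N)cc2)CC1`: 32.2%

In a functional assay on HepG2 cells (Homo sapiens) for antiproliferative activity, read by CCK-8 assay, with a stated time of 72 h, tested at 8 uM (on this read-out lower numbers stand for a weaker effect and higher numbers for a stronger effect at the one concentration tested), compound 1 gives 34.2%. Its number lies within the usual scatter of both compound 3 and compound 2, so the three measured compounds cannot be told apart on this read-out. Compound 4 `Nc1ccccc1NC(=O)c1ccc(CNc2nc(Cl)nc3c2ncn3Cc2ccccc2)cc1` is not yet measured. It differs from compound 1 in one place: phenyl in place of 2,2-dimethoxyethyl on a saturated chain carbon bound to an aromatic nitrogen. Going by the values given here, no measured pair shows this change, so there is nothing to say how large its effect is. Compound 4 is therefore expected to give 36%, within 20% to 52%, an estimated step of a number 1.8 percentage points higher from compound 1 to compound 4 (within the scatter) that is expected to stay within the scatter.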

Compound 4, a percentage reported as inhibition, at one concentration (the size of the read-out at that concentration, not a potency): 5.32%
For compound 4 the middle estimate is 30.7 percentage points above the measured one; the whole stated range lies above it.
By their numbers in this assay, from the lowest: compound 4; then compounds 3, 1 and 2 (each within the scatter of the next).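

In this assay, going by these compounds alone, the group on a saturated chain carbon bound to an aromatic nitrogen proves to matter: phenyl in place of 2,2-dimethoxyethyl gives a number 28.9 percentage points lower from compound 1 to compound 4 (beyond the scatter) and is the only step here that can be read. The two groups have the same heavy-atom count, so that count alone does not settle the number at this position. Nothing at hand explains the drop.

On these data alone, whether the aromatic ring or the loss of the two oxygens matters remains open. A carboxylic acid or an amine at the end of the chain could separate these.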